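A few compounds are considered here, and "the series" means these few. Any claim that something is new, unique, unknown or untested is made for them only; others in the source may bear on it.

Measured compounds:
compound 1 `CC(CCc1ccc(OCc2ccc3ccccc3n2)cc1)Cc1nnn[nH]1`: 25 nM
compound 2 `O=C(O)CCCOc1ccc(OCc2ccc3ccccc3n2)cc1`: 1200 nM
compound 3 `c1cc(OCCCc2nnn[nH]2)cc(OCc2ccc3ccccc3n2)c1`: 42 nM

In an assay on membranes from lung (Cavia porcellus) for binding affinity to cysteinyl leukotriene receptor (Homo sapiens) (on this read-out higher numbers stand for weaker inhibition and lower numbers for stronger inhibition), compound 3 gives 42 nM, the second highest of the three numbers. Compound 1 gives 25 nM, which lies within the scatter of compound 3, so the two cannot be ordered. Compound 2 gives 1200 nM, a number beyond the scatter above compound 3. Compound 4 `c1cc(CCCCc2nnn[nH]2)cc(OCc2ccc3ccccc3n2)c1` has not been measured. It differs from compound 3 by 4-(1H-tetrazol-5-yl)butyl in place of 3-(1H-tetrazol-5-yl)propoxy on an aromatic carbon. For the measured compounds named here, no measured pair shows this exact exchange. Compound 1 carries an all-carbon chain and gives 25 nM, close to compound 3, so no step beyond the scatter is expected. Compound 4 is therefore expected to give 40 nM, between 15 nM and 120 nM, an expected step of a 1.1-fold lower number from compound 3 to compound 4 (0.02 log units; within the scatter).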

Compound 4, inhibition constant: 20 nM
For compound 4 the middle estimate is 2.0-fold (0.30 log units) above the measured one; the measured number falls inside the stated range.
By their numbers in this assay, from the lowest: compounds 4, 1 and 3 (each within the scatter of the next, the first and the last beyond it); then compound 2.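

In this assay, putting 4-(1H-tetrazol-5-yl)butyl in place of 3-(1H-tetrazol-5-yl)propoxy on this aromatic carbon brings a 2.1-fold lower number from compound 3 to compound 4 (0.32 log units; beyond the scatter). This is a modest step, but it shows that the chain oxygen at this position is not required for binding, since the all-carbon chain gives the lower number. No measurement at hand accounts for the step. The compounds shown leave open whether a longer chain ending in the tetrazole, or a carboxylic acid in place of the tetrazole on this butyl chain, would keep this number.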